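The source may report more compounds than this note shows. Statements on the series, on what has been measured and on what is new or still open speak of the compounds shown alone.

Of the compounds shown here, three have been measured here, all sharing a six-membered ring with a urea built into it. Compound 1, `CC1=C(C(=O)OC(C)C)C(c2cccs2)NC(=O)N1C`, and compound 2, `CC1=C(C(=O)OC(C)(C)C)C(c2cccs2)NC(=O)N1C`, carry a thiophene on the core. In an assay on membranes from HeLa cells for displacement of a labelled ligand from adenosine receptor A3 (Homo sapiens), read by scintillation counting, with a stated time of 180 min, tested at 1 uM (on this read-out lower numbers stand for less inhibition and higher numbers for more inhibition at the one concentration tested (going by the name of the read-out)), compound 1 gives 17%, and compound 2 gives 22%. The only difference between them is methyl in place of hydrogen on a saturated chain carbon bound to an oxygen next to a carbonyl group and two saturated chain carbons, and that change moved the read-out by a number 5 percentage points higher from compound 1 to compound 2 (within the scatter), which is a step too small to be told from repeat measurements.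

Compound 3, `CCCC(=O)C1=C(C)NC(=O)NC1c1ccoc1`, has a different core: a furan in place of the thiophene, a ketone in place of the ester, and no methyl on the ring nitrogen. How its core differs from that of compound 1 is not broken down here. In this assay compound 3 gives 2%, the lowest of the three numbers and beyond the scatter from both others.

Compound 4, `CC1=C(C(=O)CC(C)C)C(c2ccoc2)NC(=O)N1`, is compound 3 with one alteration: methyl in place of hydrogen on a saturated chain carbon bound to two saturated chain carbons. Among the measured compounds shown here, this is the same kind of change as the one from compound 1 to compound 2, though not the same, since there the carbon also carried an oxygen next to a carbonyl group, whereas here the carbon is bound only to two saturated chain carbons. Because the earlier step was a number 5 percentage points higher from compound 1 to compound 2 (within the scatter), the step from compound 3 to compound 4 is expected to be similar in size, about a number 4 percentage points higher from compound 3 to compound 4 (within the scatter). Compound 4 is therefore estimated to give roughly 6%, likely between 0% and 16%.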

Compound 4, a percentage reported as inhibition, at one concentration (the size of the read-out at that concentration, not a potency): 18%
The estimate for compound 4 lay 12 percentage points below the measured number; measured number outside the range, above it.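

Adding the methyl that turns propylcarbonyl into isobutylcarbonyl gives, in this assay, a number 16 percentage points higher from compound 3 to compound 4 (beyond the scatter), so on this core the change produces a step that can be told from repeat measurements. Set beside the earlier step, the new one cannot be separated from it, which means the data fit a change that carries from one core to the other with much the same effect, even though only the new step stands clear of the scatter on its own: the same change on two cores in this assay, a number 5 percentage points higher (within the scatter) from compound 1 to compound 2 and a number 16 percentage points higher (beyond the scatter) from compound 3 to compound 4, 11 percentage points apart, within the scatter of two such steps This does not prove that the effect is the same on both cores, since it rests on just two pairs of compounds, the carbon that takes the methyl has different neighbours in each pair, and every number is a single reading at one concentration rather than a potency, so nothing can be said yet about a third core.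

The compounds shown leave open whether the rise continues with a longer chain in place of the isobutyl group, or whether it survives an amine or a carboxylic acid on that chain. They also leave open how the same methyl would behave on the core of compound 1 with a ketone in place of the ester.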